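Taking Undecyl off the Long Chain of Compound 1

The source may hold more compounds than are shown below. What is called first, only, known or untested is meant among the compounds shown, and "the series" means these compounds.

- Compound 1 `CCCCCCCCCCCCCCCCCCCCCCCCc1cn([C@@H](CO)[C@H](O)[C@H](O)CCCCCCCCCCCCCC)nn1`: > 50000 nM
- Compound 2 `CCCCCCCCCCCCC/C=C/[C@@H](O)[C@H](CO)n1cc(CCCCCCCCCCCCC)nn1`: > 50000 nM
- Compound 3 `CCCCCCCCCCCCC/C=C/[C@@H](O)[C@H](CO)n1cc(CCCCCCCCCCCCCCCCCCCCCCCC)nn1`: > 50000 nM

All three compounds were tested in a functional assay on K562 cells (Homo sapiens) for cytotoxicity, read by MTT assay; a lower number here means that less compound is needed, a higher number that more compound is needed for the effect. Compound 1 stands at > 50000 nM, which is a limit and not a number. The picture so far is the limit of > 50000 nM in this assay, at which 3 of the 3 values shown sit.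

Compound 4 `CCCCCCCCCCCCCC[C@@H](O)[C@@H](O)[C@H](CO)n1cc(CCCCCCCCCCCCC)nn1` is reached from compound 1 by hydrogen in place of undecyl on a saturated chain carbon, ten or more bonds along the chain from an aromatic carbon. In words, this is hydrogen in place of undecyl on a saturated chain carbon, ten or more bonds along the chain from an aromatic carbon. Going by the values given here, the one measured step of this kind is a step that the two limits leave unreadable from compound 2 to compound 3, so it gives no size or direction to carry over. No readable step is therefore expected in this assay. The expected change is a number no higher from compound 1 to compound 4 (the limit leaves the size open). Compound 4 is estimated at 50000 nM, with an expected range of 15000 nM to 100000 nM.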

Compound 4, half-maximal effective concentration: > 50000 nM
Compound 4: only a limit was reported; the forecaster's own chance of this, stated with the estimate: 80%; the middle value sits exactly at the limit.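

Compound 1 and compound 4 are both reported only as limits and not as numbers, so no step can be read between them. The compounds shown leave open how much of each would be needed for an effect in this assay, and whether hydrogen in place of undecyl changes that amount.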